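Swapping an alkyne for an ester at the oxime ether

The source may hold more compounds than are shown below. What is called first, only, known or untested is meant among the compounds shown, and "the series" means these compounds.

Measured so far, in a physicochemical assay for lipophilicity, using the shake flask method; on this read-out lower numbers stand for lower lipophilicity and higher numbers for higher lipophilicity:
- Compound 1, `Nc1ncnc(Oc2ccc(NC(=O)C3(C(=O)Nc4ccc(F)cc4)CC3)cc2F)c1/C=N/OCCCO`, gives 2.67.
- Compound 2, `Nc1ncnc(Oc2ccc(NC(=O)C3(C(=O)Nc4ccc(F)cc4)CC3)cc2F)c1/C=N/OCCO`, gives 2.37.
- Compound 3, `C#CCO/N=C/c1c(N)ncnc1Oc1ccc(NC(=O)C2(C(=O)Nc3ccc(F)cc3)CC2)cc1F`, gives 3.34.

Compound 3 stands highest of the three; the step of a number 0.67 log units higher from compound 1 to compound 3 (beyond the scatter) and the step of a number 0.97 log units higher from compound 2 to compound 3 (beyond the scatter) both put it clearly above the other two. Compound 1 and compound 2 differ from each other by a number 0.30 log units lower from compound 1 to compound 2 (within the scatter), which falls within the scatter.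

Compound 4, `CCOC(=O)CO/N=C/c1c(N)ncnc1Oc1ccc(NC(=O)C2(C(=O)Nc3ccc(F)cc3)CC2)cc1F`, has not yet been measured. Compared with compound 3 the change is ethoxycarbonyl in place of ethynyl on a saturated chain carbon bound to an oxygen on an unsaturated carbon. Among the measured compounds shown here, no measured step contains this exchange. The two steps that do involve the ethynyl group, a number 0.67 log units higher from compound 1 to compound 3 (beyond the scatter) and a number 0.97 log units higher from compound 2 to compound 3 (beyond the scatter), both show that the ethynyl analogue sits above chains carrying a hydroxy group. The ethoxycarbonyl group brings two hydrogen-bond acceptors and no donor, so the measured steps give only a loose guide. Compound 4 is therefore expected to come out somewhat below compound 3, a step of a number 0.34 log units lower from compound 3 to compound 4 (beyond the scatter) in this assay, but not as low as compound 2. The estimate for compound 4 is 3, with a range from 2.5 to 3.5.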

Compound 4, partition coefficient: 3.15
Compound 4: the middle estimate sits 0.15 log units below what was measured; the measured number falls inside the stated range.
By their numbers in this assay, from the lowest: compounds 2 and 1 (each within the scatter of the next); then compounds 4 and 3 (each within the scatter of the next).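

In this assay, the step of a number 0.19 log units lower from compound 3 to compound 4 (within the scatter) shows that this position accepts ethoxycarbonyl, with 5 heavy atoms and 2 hydrogen-bond acceptors, in place of ethynyl, with 2 heavy atoms and 0 hydrogen-bond acceptors, with no difference that stands clear of the scatter. The steps of a number 0.78 log units higher from compound 2 to compound 4 (beyond the scatter) and a number 0.48 log units higher from compound 1 to compound 4 (beyond the scatter) place the new chain clearly above both chains that end in a hydroxy group, so among these four compounds, with none going against it, both chains without a hydroxy group stand above both chains with one. Nothing measured here explains why the chains fall in this order.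

On these data alone, it remains open whether a carboxylic acid, a primary amide or a longer chain carrying the ethoxycarbonyl group would stay close to compound 4 or drop towards compound 2. A methoxycarbonyl group would begin to show how much the ethyl part of the ester contributes to the number for compound 4 in this assay, a question these compounds cannot settle.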